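Swapping an indole amide for a cinnamoyl amide

The compounds below may be only part of what the source reports. "The series", "measured", "known", "first", "only" and "open" are said of these compounds alone.

Of the compounds shown here, three have been tested for their ability to kill a human colon cancer cell line. Compound 1 `CCCCCCCCCCCCNC(=O)[C@@H](NC(=O)c1cc2ccccc2n1C)[C@@H](C)O` gives in a functional assay on SW-620 cells (Homo sapiens) for cytotoxicity, read by MTT assay, with a stated time of 48 h; on this read-out lower numbers stand for stronger inhibition and higher numbers for weaker inhibition > 200000 nM, which is a limit of the assay rather than a number. Compound 2 `CCCCCCCCCCCCNC(=O)[C@@H](NC(=O)/C=C/c1ccccc1)[C@@H](C)O` differs from it only by 2-phenylethenyl in place of 1-methyl-1H-indol-2-yl on a carbonyl carbon and gives 200000 nM. The step of a number no higher from compound 1 to compound 2 (the limit leaves the size open) cannot be sized because compound 1 sits at the limit of > 200000 nM in this assay, at which 1 of the 3 values shown sits. Compound 3 `CCCCCCCCCCCCCCCCCCNC(=O)[C@@H](NC(=O)c1cc2ccccc2n1C)[C@@H](C)O` carries a longer chain, (hexyl in place of hydrogen on a saturated chain carbon, ten or more bonds along the chain from an amide-type nitrogen), and gives 124000 nM; that is an at least 1.6-fold lower number from compound 1 to compound 3 (0.20 log units; that floor lies within the scatter). Compound 4 `CCCCCCCCCCCCCCCCCCNC(=O)[C@@H](NC(=O)/C=C/c1ccccc1)[C@@H](C)O` has not yet been measured; it differs from compound 3 by 2-phenylethenyl in place of 1-methyl-1H-indol-2-yl on a carbonyl carbon, the same change, at the same place, that already turned compound 1 into compound 2. The expectation for compound 4 rests on compound 3 at 124000 nM and on the earlier step of a number no higher from compound 1 to compound 2 (the limit leaves the size open), whose size is not readable. The step for compound 4 is therefore expected to be about a 1.0-fold higher number from compound 3 to compound 4 (0.02 log units; within the scatter). Compound 4 is estimated at 130000 nM, most likely between 50000 nM and 250000 nM.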

Compound 4, half-maximal inhibitory concentration: 200000 nM
Estimate against measurement, compound 4: 1.5-fold (0.19 log units) below; low and high end bracket the measured number.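

In this assay, putting 2-phenylethenyl in place of 1-methyl-1H-indol-2-yl on the longer-chain core gives a 1.6-fold higher number from compound 3 to compound 4 (0.21 log units; within the scatter), while hexyl in place of hydrogen on the chain, with 2-phenylethenyl held fixed, gives no change at the digits printed from compound 2 to compound 4 (within the scatter). On the longer-chain core, then, the swap shows no effect that can be told from the scatter, but this does not establish that it behaves the same way on the shorter-chain core: the same change on two cores in this assay, a number no higher (the limit leaves the size open) from compound 1 to compound 2 and a 1.6-fold higher number (0.21 log units; within the scatter) from compound 3 to compound 4; the limit leaves it open whether they differ Compound 1 stands at a limit of the assay rather than at a number, so the steps that start from it cannot be read and the swap cannot be sized on that core: the limit of > 200000 nM in this assay, at which 1 of the 4 values shown sits.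

As far as these compounds go, it remains open whether any change at this carbonyl can move the number beyond the scatter, for example an amine or a carboxylic acid on the aromatic ring of the 2-phenylethenyl group. From the compounds shown here alone, it is also open how a still longer chain on the amide nitrogen would read out on either core.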